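The source may hold more compounds than are shown below. What is called first, only, known or untested is meant among the compounds shown, and "the series" means these compounds.

Three compounds share one fused core carrying a phenyl group and a methoxylated aryl ring, and each has been tested in a functional assay on A549 cells (Homo sapiens) for antiproliferative activity, read by MTT assay, with a stated time of 24 h; a lower number here means a stronger inhibitor, a higher number a weaker inhibitor. Compound 1 `COc1ccc(C(=O)/C=C/c2cc(-c3cc(OC)c(OC)c(OC)c3)n3nc(-c4ccccc4)cc3n2)cc1` gives 14600 nM. Compound 2 `COc1cc(-c2cc(C(=O)/C=C/c3ccc(Cl)cc3)nc3cc(-c4ccccc4)nn23)cc(OC)c1OC` gives 23800 nM, and compound 3 `COc1ccc(-c2cc(C(=O)/C=C/c3ccc(Cl)cc3)nc3cc(-c4ccccc4)nn23)cc1OC` gives 22000 nM. The move from compound 1 to compound 2 is a 1.6-fold higher number from compound 1 to compound 2 (0.21 log units; within the scatter), and the move from compound 2 to compound 3 is a 1.1-fold lower number from compound 2 to compound 3 (0.03 log units; within the scatter), so compound 2 sits among the three without separating from either neighbour beyond the scatter.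

Compound 4 `COc1cc(-c2cc(/C=C/C(=O)c3ccccc3)nc3cc(-c4ccccc4)nn23)cc(OC)c1OC` has not yet been measured in this assay. It differs from compound 2 in one place: 2-benzoylethenyl in place of (2-(4-chlorophenyl)ethenyl)carbonyl on an aromatic carbon. Going by the values given here, the only measured step that touches the same part of the molecule is the one from compound 1 to compound 2, which reversed the enone and swapped the para substituent, and it stayed within the scatter. On that basis no step beyond the scatter is expected, and compound 4 is estimated to give 19000 nM, between 8000 nM and 45000 nM, a move of a 1.3-fold lower number from compound 2 to compound 4 (0.10 log units; within the scatter).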

Compound 4, half-maximal inhibitory concentration: 18200 nM
Beside the measured number, compound 4's estimate is 1.0-fold (0.02 log units) above it, and the stated range covers the measured number.
By their numbers in this assay, from the lowest: compounds 1, 4, 3 and 2 (each within the scatter of the next).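

Putting 2-benzoylethenyl in place of (2-(4-chlorophenyl)ethenyl)carbonyl on this aromatic carbon gives a 1.3-fold lower number from compound 2 to compound 4 (0.12 log units; within the scatter), so in this assay this position shows no step beyond the scatter for this exchange. Compound 4 also gives a second reading of a change already seen elsewhere, since hydrogen in place of methoxy on an aromatic carbon gives a 1.2-fold higher number from compound 1 to compound 4 (0.10 log units; within the scatter). That change can now be compared across two settings, and the two readings agree within the scatter: the same change on two cores in this assay, a 1.1-fold lower number (0.03 log units; within the scatter) from compound 2 to compound 3 and a 1.2-fold higher number (0.10 log units; within the scatter) from compound 1 to compound 4, 1.3-fold (0.13 log units) apart, within the scatter of two such steps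

Each of the four numbers lies within the scatter of the next. The compounds shown do not reveal what at this position could separate one compound from another. Going by these compounds, an amine or a carboxylic acid on the benzoyl ring, or a longer chain in place of 2-benzoylethenyl, remains open.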